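The source may report more compounds than this note shows. Statements on the series, on what has been measured and on what is new or still open speak of the compounds shown alone.

Compound 1 `C=C1C[C@]23C[C@@]1(O)CC[C@@H]2c1cccc(C)c1[C@@H]3Cn1cc(-c2ccc(OC)cc2)nn1` is the starting point. In a functional assay on MCF7 cells (Homo sapiens) for cytotoxicity, read by MTT assay, with a stated time of 4 days (on this read-out lower numbers stand for stronger inhibition and higher numbers for weaker inhibition), compound 1 gives > 20000 nM, which is a limit of the assay rather than a number. Compound 2 `Cc1ccc(-c2cn(C[C@H]3c4c(ccc(OS(=O)(=O)c5ccc(C)cc5)c4C)[C@@H]4CC[C@@]5(C)C[C@]43CC5=O)nn2)cc1` was measured in this assay as well: compound 2 gives > 20000 nM, again only a limit. Among the measured compounds shown here, both measurements stop at the same point, (the limit of > 20000 nM in this assay, at which 2 of the 2 values shown sit), so no step between measured compounds can be read off. Compound 3 `C=C1C[C@]23C[C@@]1(O)CC[C@@H]2c1cccc(C)c1[C@@H]3Cn1cc(-c2ccc(C(F)(F)F)cc2)nn1` differs from compound 1 in one place, (trifluoromethyl in place of methoxy on an aromatic carbon), that is, trifluoromethyl in place of methoxy on an aromatic carbon. Compound 3 is expected to give about 40000 nM, somewhere between 10000 nM and 150000 nM, so the step that the limit leaves unreadable from compound 1 to compound 3 is expected to stay within the usual scatter.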

Compound 3, half-maximal inhibitory concentration: > 20000 nM
Compound 3 gave a limit, no number; the forecaster's own chance of this, stated with the estimate: 80%; the middle value lies beyond the limit too.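

No step can be read from compound 1 to compound 3: both values are limits of the assay, not numbers. The compounds shown leave open how strongly either acts in this assay and whether methoxy and trifluoromethyl differ there at all.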